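Amide nitrogen swap in the toluidine-free methoxy series

This account rests on a few compounds, and the source may have more. Where it says the series, first, only, none or still open, it means among the compounds named here.

Compound 1 `C#CCNC(=O)/C(C)=C(\C)c1ccc(OC)cc1` gives 400 mg/kg in a toxicity assay on the whole organism (strain Icem-CET (SPF Caw)) for cytotoxicity, with Mus musculus as the target; on this read-out lower numbers stand for an effect already at smaller amounts and higher numbers for an effect only at larger amounts of compound. Compound 2 `C#CCNC(=O)/C(C)=C(\C)c1ccc(Cl)cc1` gives 400 mg/kg in this assay, and compound 3 `C#CCNC(=O)/C(C)=C(\C)c1ccc(C)cc1` gives 200 mg/kg. Compound 1 stands level with compound 2 (no change at the digits printed from compound 1 to compound 2 (within the scatter)), and the step of a 2.0-fold lower number from compound 1 to compound 3 (0.30 log units; within the scatter) stays inside the scatter, as does a 2.0-fold lower number from compound 2 to compound 3 (0.30 log units; within the scatter). Compound 4 `COc1ccc(/C(C)=C(\C)C(=O)NC2CC2)cc1` carries cyclopropyl in place of propargyl on an amide-type nitrogen. Among the measured compounds shown here, none of the measured steps touches this position; all three vary only the aromatic substituent and none moves this assay beyond its scatter. For the measured compounds named here, no step therefore speaks for a shift, and the expected step of no change at the digits printed from compound 1 to compound 4 (within the scatter) is none beyond the scatter. Compound 4 is estimated at 400 mg/kg in this assay, within 200 mg/kg to 800 mg/kg.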

Compound 4, dose for half-maximal effect: 300 mg/kg
For compound 4 the middle estimate is 1.3-fold (0.12 log units) above the measured one, within the range that was stated.
By their numbers in this assay, from the lowest: compounds 3, 4, 1 and 2 (each within the scatter of the next).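

The amide nitrogen now has its first reading: cyclopropyl in place of propargyl gives a 1.3-fold lower number from compound 1 to compound 4 (0.12 log units; within the scatter) in this assay. Exchanging the triple bond for a three-membered carbon ring, at the same count of heavy atoms, therefore stays inside the scatter, so in the methoxy compounds the propargyl group is not needed to hold this level. Nothing at hand bears on why the number holds.

Open, on these data alone, is whether a longer chain, a benzyl group or an aminoethyl chain on this nitrogen also stays within the scatter. Also open, as far as these compounds go, is whether cyclopropyl behaves the same with chloro or methyl in place of methoxy.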